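The source may report more compounds than this note shows. Statements on the series, on what has been measured and on what is new or still open speak of the compounds shown alone.

Compound 1 `Oc1cccc2[nH]c(-c3ccc(-c4ccc(-c5ccc(F)cc5)cc4)cc3)nc12` and compound 2 `Oc1cccc2[nH]c(-c3ccc(-c4ccc(-c5ccc(C(F)(F)F)cc5)cc4)cc3)nc12` share one core, while compound 3 `Cc1ccc2[nH]c(-c3ccc(-c4ccc(-c5ccc(F)cc5)cc4)cc3)nc2c1` and the not yet measured compound 4 `Cc1ccc2[nH]c(-c3ccc(-c4ccc(-c5ccc(C(F)(F)F)cc5)cc4)cc3)nc2c1` share another; the difference between the two cores is not broken down here. In a functional assay on ZR-75-1 cells (Homo sapiens) for inhibition, read by sulforhodamine B assay (a lower number here means a stronger inhibitor of growth, a higher number a weaker inhibitor of growth), compound 1 gives 6320 nM, and compound 2 gives 5110 nM. The change trifluoromethyl in place of fluoro on an aromatic carbon made a 1.2-fold lower number from compound 1 to compound 2 (0.09 log units; within the scatter). In this assay compound 3 gives 35000 nM. The same change, (trifluoromethyl in place of fluoro on an aromatic carbon), with the place described in the same words, leads from compound 3 to compound 4. Because a 1.2-fold lower number from compound 1 to compound 2 (0.09 log units; within the scatter) stayed within the scatter, the step to compound 4 is expected to be a 1.2-fold lower number from compound 3 to compound 4 (0.07 log units; within the scatter), likewise within the scatter. In this assay compound 4 is therefore estimated at 30000 nM, with a likely range from 15000 nM to 60000 nM.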

Compound 4, concentration for 50% growth inhibition: 2410 nM
Compound 4: the middle estimate sits 12-fold (1.10 log units) above what was measured; measured number outside the range, below it.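

In this assay, the change from fluoro to trifluoromethyl did not carry over between the two cores, giving a 15-fold lower number from compound 3 to compound 4 (1.16 log units; beyond the scatter), and the two steps differ: the same change on two cores in this assay, a 1.2-fold lower number (0.09 log units; within the scatter) from compound 1 to compound 2 and a 15-fold lower number (1.16 log units; beyond the scatter) from compound 3 to compound 4, 12-fold (1.07 log units) apart, beyond the scatter of two such steps With trifluoromethyl on both cores, the change of core gives a 2.1-fold lower number from compound 2 to compound 4 (0.33 log units; beyond the scatter), whereas with fluoro compound 1 gives 6320 nM and compound 3 gives 35000 nM, so the order of the two cores reverses with the group. This shows that the size of the step depends on the core in these four compounds, but it does not show why, or how the change would behave on a further core.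

The compounds shown leave open whether the hydroxy group or the methyl group on the core governs this difference. They also leave open how a chlorine, a methoxy group or an amine would behave in place of fluoro or trifluoromethyl on either core.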